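The compounds below may be only part of what the source reports. "The series", "measured", "known", "first", "only" and "open" are said of these compounds alone.

Compound 2 `NCCCNc1c(C(=O)NCc2ccc(F)cc2)nc(Br)c2cccnc12` shares its core with compound 1 `N[C@H]1CC[C@H](Nc2c(C(=O)NCc3ccco3)nc(Br)c3cccnc23)CC1` and compound 3 `N[C@H]1CC[C@H](Nc2c(C(=O)NCc3ccc(Cl)cc3Cl)nc(Br)c3cccnc23)CC1`. In a functional assay on MDA-MB-435 cells (Homo sapiens) for cytotoxicity, read by MTT assay, with a stated time of 72 h (a lower number here means a stronger inhibitor, a higher number a weaker inhibitor), compound 2 gives 5000 nM. Compound 3 gives 5800 nM in this assay, a number that sits within the scatter of the value of compound 2, so the two cannot be ranked against each other. Compound 1 gives only a limit in this assay, > 10000 nM. For the measured compounds named here, the single measured step, an at least 1.7-fold lower number from compound 1 to compound 3 (0.23 log units; that floor lies within the scatter), starts at the limit of > 10000 nM in this assay, at which 1 of the 3 values shown sits, and concerns the saturated chain carbon bound to an amide-type nitrogen, not the place changed here. Compound 4 `Cc1ccc(S(=O)(=O)Oc2c(C(=O)NCc3ccc(F)cc3)nc(Br)c3cccnc23)cc1` differs from compound 2 by ((4-methylphenyl)sulfonyl)oxy in place of (3-aminopropyl)amino on an aromatic carbon. Going by the values given here, no measured step touches this position, so the size of the coming step is open, and the measured compounds give no precedent for a change of this kind. Compound 4 is therefore expected to give 10000 nM, with a range from 3000 nM to 30000 nM. The step of a 2.0-fold higher number from compound 2 to compound 4 (0.30 log units; within the scatter) is thus expected to point toward a weaker inhibitor, with a fair chance that only a limit is reported.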

Compound 4, half-maximal inhibitory concentration: > 20000 nM
Compound 4 ended at the assay's limit; the forecaster's own chance of this, stated with the estimate: 50%; at least 2.0-fold (0.30 log units) between middle value and limit.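

Replacing (3-aminopropyl)amino with ((4-methylphenyl)sulfonyl)oxy on this aromatic carbon gives an at least 4.0-fold higher number from compound 2 to compound 4 (0.60 log units; beyond the scatter) in this assay, the first step shown that lies beyond the scatter. For the compounds shown here, the earlier compounds held no change at this position, so this is the first sign that the group on this carbon affects the number. The step gives only a floor, not a full size, as compound 4 reaches a limit of the assay: the limit of > 20000 nM in this assay, at which 1 of the 4 values shown sits.

The change removes both hydrogen-bond donors and adds an aromatic ring in a single step, so the compounds shown cannot separate these differences. From the compounds shown here alone, whether a small hydroxyl group or a longer chain such as (4-aminobutyl)amino on this carbon would stay close to compound 2 also remains open.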